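The compounds below may be only part of what the source reports. "The series", "measured", "known", "first", "only" and "open" are said of these compounds alone.

In a functional assay on A-375 cells (Homo sapiens) for antiproliferative activity (a lower number here means a stronger inhibitor, a higher number a weaker inhibitor), compound 1 (`O=C(NC1CCCN(Cc2ccc(F)c(F)c2)C1)c1ccc(-c2cscn2)cc1`) is reported only as a limit, > 20000 nM.

Compound 2 (`O=C(Nc1ccc(-c2cscn2)cc1)[C@H]1CCCN(Cc2ccc(F)c(F)c2)C1`) gives 190 nM, and compound 3 (`O=C(Nc1ccc(-c2cscn2)cc1)C1CCCN(Cc2ccccc2F)C1`) gives 4000 nM. Compound 3 therefore has the higher of the two actual numbers, and the gap to compound 2 lies beyond the scatter.

The next compound to be tested is compound 4 (`O=C(Nc1ccc(-c2cscn2)cc1)C1CCCN(Cc2cccnc2)C1`). It carries pyridin-3-yl in place of the 2-fluorophenyl of compound 3, on a saturated chain carbon bound to an amine nitrogen in a ring: pyridin-3-yl in place of 2-fluorophenyl on a saturated chain carbon bound to an amine nitrogen in a ring.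

Among the measured compounds shown here, no measured step in this assay covers this exchange, so the expectation starts from compound 3 at 4000 nM and remains loose. A small move toward a weaker number is expected, with the estimated step of a 2.0-fold higher number from compound 3 to compound 4 (0.30 log units; within the scatter) lying close to the scatter.

For compound 4 the expected value is 8000 nM, with an estimated range of 2500 nM to 20000 nM.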

Compound 4, half-maximal inhibitory concentration: > 20000 nM
Compound 4 was reported as a limit; the forecaster's own chance of this, stated with the estimate: 20%; middle value at least 2.5-fold (0.39 log units) away from the limit.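

In this assay, the aromatic ring on a saturated chain carbon bound to an amine nitrogen in a ring is sensitive to exchange, with an at least 5.0-fold higher number from compound 3 to compound 4 (0.69 log units; beyond the scatter) for pyridin-3-yl in place of 2-fluorophenyl. Among the compounds shown here, this is the first step that changes one place only, so it is the first direct reading of this position, which the earlier compounds could not give. Compound 4 is reported as a limit and not as a number, so the step has a floor but no upper end: the limit of > 20000 nM in this assay, at which 2 of the 4 values shown sit.

The compounds shown do not separate the loss of the fluorine from the entry of the ring nitrogen. Plain phenyl or pyridin-2-yl at the same place would bear on that question, and on whether any nitrogen in this ring is tolerated.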